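Series notes: amide ring swap on compound 2

This account rests on a few compounds, and the source may have more. Where it says the series, first, only, none or still open, it means among the compounds named here.

Measured so far in a physicochemical assay for lipophilicity, read by HPLC, at pH 3.0; on this read-out higher numbers stand for higher lipophilicity and lower numbers for lower lipophilicity:
compound 1 `NCc1csc(NC(=O)c2cc3ccccc3n2Cc2ccccc2)n1` — 2.4
compound 2 `Cc1csc(NC(=O)c2cc(C(C)(C)C)nn2Cc2ccccc2)n1` — 4.7
compound 3 `CC(C)(C)c1cc(C(=O)Nc2nc(CNS(C)(=O)=O)cs2)n(Cc2ccccc2)n1` — 3.7

Compound 2 carries the highest number of the three in this assay. Going by the values given here, its nearest neighbour is compound 3, reached by a number 1.00 log units lower from compound 2 to compound 3 (beyond the scatter); compound 1 sits further off, and no single-change step links compound 1 to either of the others.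

Compound 4 `CC(C)(C)c1cc(C(=O)Nc2cccnc2)n(Cc2ccccc2)n1` is the next structure to be read. It differs from compound 2 by pyridin-3-yl in place of 4-methyl-1,3-thiazol-2-yl on an amide-type nitrogen. Among the compounds with values here, the one measured step, from compound 2 to compound 3, concerns a methanesulfonamido added on a saturated chain carbon and not an exchange of the ring on the amide-type nitrogen, so it offers no direct precedent here. Within the data shown here, the data therefore give no step of the same kind to lean on.

Working from the ring exchange alone, a decrease in this assay beyond the scatter is expected for compound 4, estimated as a number 1.00 log units lower from compound 2 to compound 4 (beyond the scatter). Compound 4 is thus expected to give about 3.7, within 3 to 4.4.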

Compound 4, distribution coefficient: 3.5
The estimate for compound 4 lay 0.20 log units above the measured number; measured number inside the range.
By their numbers in this assay, from the lowest: compound 1; then compounds 4 and 3 (each within the scatter of the next); then compound 2.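

Within this assay, compound 4 gives the first reading of a ring exchange on the amide-type nitrogen, with a number 1.20 log units lower from compound 2 to compound 4 (beyond the scatter). The number therefore responds clearly to the identity of this ring, even though 6 heavy atoms leave and 6 heavy atoms enter and neither group has a net charge. What does change is the ring type, from a five-membered aromatic ring with 2 hetero atoms to a six-membered aromatic ring with 1 hetero atom, but nothing available explains the size of this step.

A single exchange cannot separate the contribution of the ring from that of its methyl group. A plain phenyl or an unsubstituted 1,3-thiazol-2-yl on the same nitrogen would divide the step between those two parts.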